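The source may report more compounds than this note shows. Statements on the series, on what has been measured and on what is new or still open speak of the compounds shown alone.

Compound 1 `CCCC/C=C\CCCCCCCCCc1cc(=O)c2c(O)cc(O)c(C)c2o1` is measured in a functional assay on MCF7 cells (Homo sapiens) for antiproliferative activity, read by MTT assay (on this read-out lower numbers stand for stronger inhibition and higher numbers for weaker inhibition), where compound 1 gives 17500 nM. Two companions sit with it in this assay: compound 2 `CCCCC/C=C\C/C=C\CCCCCCCC1(O)CC(=O)c2c(O)cc(O)cc2O1` gives 17500 nM and compound 3 `CCCCCCCCCCCCCCCc1cc(=O)c2c(O)cc(O)c(C)c2o1` gives 17500 nM. All three values stand at the same level within the scatter, so no order among them can be read. For the measured compounds named here, the one single-point step in the set, no change at the digits printed from compound 1 to compound 3 (within the scatter), concerns the chain only and leaves the read-out unchanged.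

Compound 4 `CCCC/C=C\CCCCCCCCCc1cc(=O)c2c(O)cc(OCOC)c(C)c2o1` is the next member. Its difference from compound 1: methoxymethyl in place of hydrogen on an oxygen on an aromatic ring. Going by the values given here, no measured step touches this oxygen on the aromatic ring; the only measured step, no change at the digits printed from compound 1 to compound 3 (within the scatter), sits far along the chain and therefore says nothing direct about capping a hydroxy. With nothing to point either way, the expectation for compound 4 is a step of about no change at the digits printed from compound 1 to compound 4 (within the scatter), that is, no change beyond the scatter. Compound 4 is thus estimated to give 17500 nM in this assay, within a range from 7000 nM to 45000 nM.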

Compound 4, half-maximal inhibitory concentration: > 67200 nM
Compound 4 was reported as a limit; the forecaster's own chance of this, stated with the estimate: 10%; middle value at least 3.8-fold (0.58 log units) away from the limit.
By their numbers in this assay, from the lowest: compounds 1, 2 and 3 (each within the scatter of the next). At a limit, above all of these: compound 4.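

In this assay compound 4 gives > 67200 nM as a limit of the assay and not as a number. Methoxymethyl on this oxygen on an aromatic ring produces an at least 3.8-fold higher number from compound 1 to compound 4 (0.58 log units; beyond the scatter) and is thus the only change shown that moves the read-out beyond the scatter. The sole earlier step, no change at the digits printed from compound 1 to compound 3 (within the scatter) in the chain, gave no such sign, so this oxygen is the one place shown so far where a change registers in the read-out.

From the compounds shown here alone, whether the loss follows from capping the hydroxy as such or from methoxymethyl in particular stays open, and a methyl ether or an acetate on the same oxygen would separate the two. The full size of the step also stays open, with only one bound on it: the limit of > 67200 nM in this assay, at which 1 of the 4 values shown sits.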